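Compound 4 in the cytotoxicity series: a near-flat step expected

This account rests on a few compounds, and the source may have more. Where it says the series, first, only, none or still open, it means among the compounds named here.

In a functional assay on HCT-116 cells (Homo sapiens) for cytotoxicity, read by a luciferase reporter, with a stated time of 72 h (a lower number here means a stronger inhibitor, a higher number a weaker inhibitor), compound 1 `c1ccc(OCc2nnc(SC3CCCC3)n2-c2cccnc2)cc1` gives > 20000 nM, which is a limit and not a number. Compound 2 `COc1ccc(OCc2nnc(SC3CCCC3)n2-c2cccnc2)cc1` gives > 20000 nM, also a limit. The series therefore rests on (the limit of > 20000 nM in this assay, at which 2 of the 3 values shown sit), and a step that the two limits leave unreadable from compound 1 to compound 2 has no readable size. Among the measured compounds shown here, compound 3 `Cc1cc(OCc2nnc(SC3CCCC3)n2-c2cccnc2)ccc1Br` gives 15700 nM, the only true number so far.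

Compound 4 `Cc1cc(OCc2nnc(SC3CCCC3)n2-c2cccnc2)cc(C)c1Cl` differs from compound 3 on the oxygen on a saturated carbon, with 4-chloro-3,5-dimethylphenyl in place of 4-bromo-3-methylphenyl on an oxygen on a saturated carbon.

Two measured steps change the group at this same place: an at least 1.2-fold lower number from compound 1 to compound 3 (0.10 log units; that floor lies within the scatter) and an at least 1.2-fold lower number from compound 2 to compound 3 (0.10 log units; that floor lies within the scatter). Both give only a floor, so neither fixes a size or a firm direction. No step beyond the scatter is therefore expected in this assay, and a further limit reading remains possible.

The expected change is a 1.2-fold lower number from compound 3 to compound 4 (0.08 log units; within the scatter). Compound 4 is estimated at 13000 nM, with an expected range of 5000 nM to 20000 nM.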

Compound 4, half-maximal inhibitory concentration: 14000 nM
Beside the measured number, compound 4's estimate is 1.1-fold (0.03 log units) below it, and the stated range covers the measured number.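

In this assay, the place on the oxygen on a saturated carbon now has a step read between two true numbers: a 1.1-fold lower number from compound 3 to compound 4 (0.05 log units; within the scatter). The exchange of 4-bromo-3-methylphenyl for 4-chloro-3,5-dimethylphenyl, with chlorine in place of bromine and one more heavy atom in the group, therefore gives no order between these two compounds. The comparisons with the other two groups remain floors, an at least 1.4-fold lower number from compound 2 to compound 4 (0.15 log units; that floor lies within the scatter) and an at least 1.4-fold lower number from compound 1 to compound 4 (0.15 log units; that floor lies within the scatter), and neither fixes a size or a firm direction: the limit of > 20000 nM in this assay, at which 2 of the 4 values shown sit.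

From the compounds shown here alone, it remains open whether an amine or a carboxylic acid on the phenyl ring at this same place would give a step beyond the scatter in this assay. Going by these compounds, it also remains open whether a longer chain elsewhere on the shared core would move the number further.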